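Rat microsomal clearance in the aryl-substituted sulfonamide series

This account rests on a few compounds, and the source may have more. Where it says the series, first, only, none or still open, it means among the compounds named here.

Measured compounds:
compound 1, `Nc1ccc(S(=O)(=O)N2CCN(c3ncc(C(O)(C(F)(F)F)C(F)(F)F)cc3C3CC3)CC2)cn1`: 27 mL.min-1.g-1
compound 2, `Nc1ccc(S(=O)(=O)N2CCN(c3ncc(C(O)(C(F)(F)F)C(F)(F)F)cc3C#CC3CC3)CC2)cn1`: 67 mL.min-1.g-1
compound 3, `CC(C)(O)C#Cc1cc(C(O)(C(F)(F)F)C(F)(F)F)cnc1N1CCN(S(=O)(=O)c2ccc(N)nc2)CC1`: 16 mL.min-1.g-1

In an ADME assay (liver) for metabolic stability, with Liver microsome (Rattus norvegicus) as the target, using microsomes and NADPH, with a stated time of 30 min, tested at 1 uM (on this read-out higher numbers stand for fast clearance and lower numbers for slow clearance), compound 1 gives 27 mL.min-1.g-1, the second highest of the three numbers; compound 3 is nearest with 16 mL.min-1.g-1, and compound 2 furthest with 67 mL.min-1.g-1. The step of a 1.7-fold lower number from compound 1 to compound 3 (0.23 log units; within the scatter) is within the scatter, whereas a 2.5-fold higher number from compound 1 to compound 2 (0.39 log units; beyond the scatter) and a 4.2-fold lower number from compound 2 to compound 3 (0.62 log units; beyond the scatter) are beyond it.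

Compound 4, `Nc1ccc(S(=O)(=O)N2CCN(c3ncc(C(O)(C(F)(F)F)C(F)(F)F)cc3-c3ccoc3)CC2)cn1`, is not yet measured. The change from compound 1: furan-3-yl in place of cyclopropyl on an aromatic carbon

Within the data shown here, no measured step replaces the cyclopropyl with an aromatic ring, so none bears directly on this change. The steps from compound 1 show that a group swap at this position can shift this assay either within the scatter, as in a 1.7-fold lower number from compound 1 to compound 3 (0.23 log units; within the scatter), or modestly beyond it, as in a 2.5-fold higher number from compound 1 to compound 2 (0.39 log units; beyond the scatter). Among the measured compounds shown here, with no closer precedent, a step from compound 1 to compound 4 of about a 1.3-fold higher number from compound 1 to compound 4 (0.11 log units; within the scatter) is expected, within the scatter, with a wide range. Compound 4 is estimated at 35 mL.min-1.g-1 (range 15 mL.min-1.g-1 to 85 mL.min-1.g-1).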

Compound 4, intrinsic clearance in microsomes: 57 mL.min-1.g-1
Beside the measured number, compound 4's estimate is 1.6-fold (0.21 log units) below it; low and high end bracket the measured number.
By their numbers in this assay, from the lowest: compounds 3 and 1 (each within the scatter of the next); then compounds 4 and 2 (each within the scatter of the next).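

Replacing cyclopropyl with an aromatic ring at this position is not neutral in this assay: furan-3-yl gives a 2.1-fold higher number from compound 1 to compound 4 (0.32 log units; beyond the scatter). The furan-3-yl and 2-cyclopropylethynyl groups cannot be told apart, with a 1.2-fold lower number from compound 2 to compound 4 (0.07 log units; within the scatter), while furan-3-yl remains clearly separate from the 3-hydroxy-3-methylbut-1-yn-1-yl group, with a 3.6-fold higher number from compound 3 to compound 4 (0.55 log units; beyond the scatter). The four compounds therefore fall into two groups, compounds 1 and 3 at the low end and compounds 2 and 4 at the high end, and the triple bond of compounds 2 and 3 does not decide the group, while no measurement offered here accounts for this split.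

On these data alone, whether a hydroxyl group on the furan-3-yl ring would lower the number, as the hydroxyl-bearing alkyne of compound 3 stands lower than compound 2, remains open. Also open, as far as these compounds go, is how an amine or a longer alkyl chain at this position would read in this assay and which of the two groups it would join.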